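The source may hold more compounds than are shown below. What is called first, only, known or untested is meant among the compounds shown, and "the series" means these compounds.

Three compounds share one core and differ only in the group carried on an aromatic carbon: compound 1 `Brc1ccccc1OCC1=NCCO1` bears bromo, compound 2 `Cc1ccccc1OCC1=NCCO1` bears methyl and compound 3 `Clc1ccccc1OCC1=NCCO1` bears chloro. In a toxicity assay on the whole organism with Rattus norvegicus as the target, at a dose of 100 mg/kg by the oral route (on this read-out higher numbers stand for a stronger effect at the one dose given and lower numbers for a weaker effect), compound 1 gives 10%, compound 2 gives 10% and compound 3 gives 40%. Compound 3 therefore stands highest of the three, since the step of a number 30 percentage points higher from compound 1 to compound 3 (beyond the scatter) and the step of a number 30 percentage points higher from compound 2 to compound 3 (beyond the scatter) both lie beyond the scatter, whereas no change at the digits printed from compound 1 to compound 2 (within the scatter). Compound 4 `Fc1ccccc1OCC1=NCCO1` has not yet been measured; it differs from compound 3 in one place, (fluoro in place of chloro on an aromatic carbon). The two steps that bear on this change are those leading into compound 3, each a modest rise, and they show that swapping one small group for another at this carbon can move the read-out, with chloro alone standing high. Among the compounds with values here, no measured step runs from chloro to fluoro, so the direction remains open. Compound 4 is estimated at 25%, within a range from 5% to 50%. For compound 4 the expected step is a number 15 percentage points lower from compound 3 to compound 4 (beyond the scatter), a modest fall, reflecting that two of the three groups tried gave the lower reading.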

Compound 4, a percentage reported as activity, at one dose (the size of the read-out at that dose, not a potency): 10%
Compound 4: the middle estimate sits 15 percentage points above what was measured; measured number inside the range.
By their numbers in this assay, from the lowest: compounds 1, 2 and 4 (each within the scatter of the next); then compound 3.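

In this assay, the change from chloro to fluoro gives a number 30 percentage points lower from compound 3 to compound 4 (beyond the scatter), the first measured step leading away from chloro on this aromatic carbon. Fluoro also sits with the other two groups, with no change at the digits printed from compound 2 to compound 4 (within the scatter) and no change at the digits printed from compound 1 to compound 4 (within the scatter), so chloro alone now stands apart among the four groups; a shared halogen pattern does not hold, as compound 1 and compound 4 carry halogens yet read with the methyl of compound 2. Nothing in the available data accounts for why chloro alone stands apart.

The compounds shown leave open whether a methoxy group, an amine or a trifluoromethyl group on this carbon would read with chloro or with the other three. They also leave open whether chloro on another carbon of the ring would keep the higher number.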